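Compound 3: changing the aryl group on the amide

The source may hold more compounds than are shown below. What is called first, only, known or untested is meant among the compounds shown, and "the series" means these compounds.

Compound 1 `O=C(CN1CCN(c2nnc(Cc3ccccc3)c3ccccc23)CC1)Nc1c(F)cccc1F`: 19700 nM
Compound 2 `O=C(CN1CCN(c2nnc(Cc3ccccc3)c3ccccc23)CC1)Nc1ccc(Br)cc1`: 60200 nM

Among the compounds with values here, in a functional assay on HT-29 cells (Homo sapiens) for cytotoxicity, read by MTT assay, with a stated time of 72 h (on this read-out higher numbers stand for weaker inhibition and lower numbers for stronger inhibition), compound 2 gives 60200 nM, the higher of the two numbers so far. Compound 3 `O=C(CN1CCN(c2nnc(Cc3ccccc3)c3ccccc23)CC1)Nc1cc(C(F)(F)F)ccc1Cl` carries 2-chloro-5-(trifluoromethyl)phenyl in place of 4-bromophenyl on an amide-type nitrogen. Within the data shown here, the only measured step at this place is a 3.1-fold higher number from compound 1 to compound 2 (0.49 log units; beyond the scatter), a modest change that lies beyond the scatter. Among the measured compounds shown here, no measured compound carries the entering group, so the direction is tentative. A step of similar size toward a lower number is expected in this assay, estimated as a 2.2-fold lower number from compound 2 to compound 3 (0.33 log units; beyond the scatter). For compound 3 the expected value is 28000 nM, with an estimated range of 10000 nM to 75000 nM.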

Compound 3, half-maximal inhibitory concentration: 66800 nM
The estimate for compound 3 lay 2.4-fold (0.38 log units) below the measured number; measured number inside the range.
By their numbers in this assay, from the lowest: compound 1; then compounds 2 and 3 (each within the scatter of the next).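

In this assay, 2-chloro-5-(trifluoromethyl)phenyl and 4-bromophenyl on the amide-type nitrogen are not separated (a 1.1-fold higher number from compound 2 to compound 3 (0.05 log units; within the scatter)), despite the different substituents on the aryl ring. Compound 1 stays apart from compound 3 as well (a 3.4-fold higher number from compound 1 to compound 3 (0.53 log units; beyond the scatter)), so 2,6-difluorophenyl is the only group shown here that gives a lower number. No measurement bearing on this result is available.

The compounds shown do not settle whether the lower number of compound 1 depends on its fluorine atoms. They also leave open how an amine or a carboxylic acid on the aryl ring would read.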